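A few compounds are considered here, and "the series" means these few. Any claim that something is new, unique, unknown or untested is made for them only; others in the source may bear on it.

Three compounds define the ground here. Compound 1 `Cn1ncc2c(-c3ccc(F)cc3)cc(NNC(=O)Nc3cc(Cl)cc(Cl)c3)nc21` gives 39100 nM in a functional assay on HCT-116 cells (Homo sapiens) for cytotoxicity, read by MTT assay, with a stated time of 48 h, in the presence of a further agent that is not named here; a higher number here means that more compound is needed for the effect, a lower number that less compound is needed; compound 2 `COc1ccc(-c2cc(NNC(=O)Nc3cc(Cl)nc(Cl)c3)nc3c2cnn3C)cc1` gives 12300 nM; compound 3 `CC(C)c1cc(NNC(=O)Nc2cc(Cl)nc(Cl)c2)nc2c1cnn2C` gives 17200 nM. Compound 3 thus stands second highest of the three numbers, closest to compound 2 and furthest from compound 1. Going by the values given here, the one single-point step measured, a 1.4-fold higher number from compound 2 to compound 3 (0.15 log units; within the scatter), stayed within the scatter. Compound 4 `Cn1ncc2c(-c3ccc(F)cc3)cc(NNC(=O)Nc3cc(Cl)nc(Cl)c3)nc21` differs from compound 3 by 4-fluorophenyl in place of isopropyl on an aromatic carbon. That change reverses the kind of swap seen in the step from compound 2 to compound 3, so the expected step of a 1.1-fold lower number from compound 3 to compound 4 (0.06 log units; within the scatter) is none beyond the scatter. Compound 4 is therefore estimated at 15000 nM in this assay, with a range from 6000 nM to 40000 nM.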

Compound 4, half-maximal effective concentration: 8210 nM
For compound 4 the middle estimate is 1.8-fold (0.26 log units) above the measured one; measured number inside the range.
By their numbers in this assay, from the lowest: compounds 4, 2 and 3 (each within the scatter of the next, the first and the last beyond it); then compound 1.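

In this assay, a 4-fluorophenyl group in place of isopropyl at this position gives a step beyond the scatter (a 2.1-fold lower number from compound 3 to compound 4 (0.32 log units; beyond the scatter)), which the 4-methoxyphenyl comparison had not shown, yet fluoro in place of methoxy on that ring stays within it (a 1.5-fold lower number from compound 2 to compound 4 (0.18 log units; within the scatter)). At the other end of the molecule, 2,6-dichloropyridin-4-yl in place of 3,5-dichlorophenyl on an amide-type nitrogen gives a larger step (a 4.8-fold lower number from compound 1 to compound 4 (0.68 log units; beyond the scatter)). Nothing available here accounts for these steps. As far as these compounds go, whether a morpholine or a carboxylic acid on that phenyl ring, or a longer chain in place of isopropyl, would shift the number remains open.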